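Fluoro step on a compound sitting at the assay limit

The source may report more compounds than this note shows. Statements on the series, on what has been measured and on what is new or still open speak of the compounds shown alone.

Of the compounds shown here, two have been read so far in a functional assay on CUTLL1 cells (Homo sapiens) for inhibition, read by resazurin assay, with a stated time of 48 h, in the presence of a further agent that is not named here; on this read-out lower numbers stand for an effect already at smaller amounts and higher numbers for an effect only at larger amounts of compound: compound 1 (`Nc1ncc(-c2ccccn2)c(C2CC2)n1`) and compound 2 (`Nc1ncc(-c2ccccc2)c(C2CC2)n1`). Compound 1 gives > 100000 nM in this assay, and that entry is a limit, not a number. Compound 2 gives > 100000 nM in this assay, again a limit and not a number. Compound 2 therefore offers no measured number as a starting point, and the record so far reads: the limit of > 100000 nM in this assay, at which 2 of the 2 values shown sit. Within the data shown here, no step between measured compounds is available to size the next change.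

Compound 3 (`Nc1ncc(-c2ccc(F)cc2)c(C2CC2)n1`) follows from compound 2 by one change, (fluoro in place of hydrogen on an aromatic carbon), which is fluoro in place of hydrogen on an aromatic carbon, para to a large group. In this assay no step beyond the usual scatter is expected, in either direction, and another limit is the most likely report. The expected a number no higher from compound 2 to compound 3 (the limit leaves the size open) stays within that scatter. For compound 3 the estimated value is 100000 nM, with an expected range from 50000 nM to 200000 nM if a number is reported at all.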

Compound 3, half-maximal effective concentration: > 100000 nM
Compound 3: only a limit was reported; the forecaster's own chance of this, stated with the estimate: 85%; the middle value sits exactly at the limit.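

Compound 2 and compound 3 are both reported only as limits, not numbers, in this assay, and no step can be read between them. The compounds shown leave open whether the fluoro in place of hydrogen has any effect, and which change to the shared core would yield a measured number, with the record so far standing at: the limit of > 100000 nM in this assay, at which 3 of the 3 values shown sit.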